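Pyridin-4-yl in place of pyridin-3-yl: an expected step

A few compounds are considered here, and "the series" means these few. Any claim that something is new, unique, unknown or untested is made for them only; others in the source may bear on it.

Compound 1 `N=C(N)N/N=C/c1c(-c2ccccn2)nc2sc(Cl)cn12`: 15100 nM
Compound 2 `N=C(N)N/N=C/c1c(-c2cccnc2)nc2sc(Cl)cn12`: 21900 nM

In a functional assay on colon cells (Homo sapiens) for antiproliferative activity (on this read-out lower numbers stand for stronger inhibition of growth and higher numbers for weaker inhibition of growth), compound 2 gives 21900 nM, a value within the scatter of compound 1 at 15100 nM. Neither compound can be ranked above the other on these numbers.

Compound 3 `N=C(N)N/N=C/c1c(-c2ccncc2)nc2sc(Cl)cn12` differs from compound 2 in one place: pyridin-4-yl in place of pyridin-3-yl on an aromatic carbon. In words, pyridin-4-yl stands in place of pyridin-3-yl on an aromatic carbon. Among the compounds with values here, one measured step bears on this change: a 1.5-fold higher number from compound 1 to compound 2 (0.16 log units; within the scatter). Within the data shown here, it is the only evidence on exchanging one pyridinyl attachment for another, and no measurement yet covers pyridin-4-yl itself.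

Resting on compound 2 at 21900 nM and on that small step, no change beyond the scatter is expected in this assay, and no direction is favoured. The expected step is a 1.1-fold lower number from compound 2 to compound 3 (0.04 log units; within the scatter). Compound 3 is estimated at 20000 nM, with an expected range from 9000 nM to 45000 nM.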

Compound 3, concentration for total growth inhibition: 27500 nM
The estimate for compound 3 lay 1.4-fold (0.14 log units) below the measured number; low and high end bracket the measured number.
By their numbers in this assay, from the lowest: compounds 1, 2 and 3 (each within the scatter of the next).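

With pyridin-4-yl in place, all three pyridinyl attachments on this aromatic carbon of the shared core can be set side by side in this assay. The change from pyridin-3-yl gives a small step (a 1.3-fold higher number from compound 2 to compound 3 (0.10 log units; within the scatter)), and the change from pyridin-2-yl also stays small (a 1.8-fold higher number from compound 1 to compound 3 (0.26 log units; within the scatter)). Every exchange among these three groups thus remains within the scatter, so on these numbers the attachment point of the pyridine does not separate the compounds. Nothing at hand offers a reason for this result.

The compounds shown leave open whether a phenyl ring, or a pyridine carrying an amine or a carboxylic acid, would move the number beyond the scatter at this place. They also leave open whether a longer chain in place of the ring would do so.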